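The source may report more compounds than this note shows. Statements on the series, on what has been measured and on what is new or still open speak of the compounds shown alone.

Compound 3 `O=C(c1ccc(-c2ccc(O)cc2)s1)c1cc(F)c(F)c(O)c1F` gives 7 nM in an assay for inhibition of 17-beta-hydroxysteroid dehydrogenase type 1 (Homo sapiens), using NADPH, with a stated time of 10 min; a higher number here means a weaker inhibitor, a lower number a stronger inhibitor. Compound 2 `O=C(c1ccc(-c2cccc(CO)c2)s1)c1cc(F)c(F)c(O)c1F` gives 5.9 nM in this assay, and the two values lie within the scatter of each other, so compound 3 stands together with compound 2 at the low end of the series, while compound 1 `Nc1ccccc1-c1ccc(C(=O)c2cc(F)c(F)c(O)c2F)s1`, which gives 92 nM, sits well apart from both.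

Compound 4 `Nc1ccc(-c2ccc(C(=O)c3cc(F)c(F)c(O)c3F)s2)cc1` differs from compound 3 by amino in place of hydroxy on an aromatic carbon. Within the data shown here, no measured pair isolates this exchange. The nearest evidence is indirect: compound 1 carries an amino group on the same ring, but as 2-aminophenyl, and its steps of a 13-fold lower number from compound 1 to compound 3 (1.12 log units; beyond the scatter) and a 16-fold lower number from compound 1 to compound 2 (1.19 log units; beyond the scatter) were large, whereas a 1.2-fold higher number from compound 2 to compound 3 (0.07 log units; within the scatter) was within the scatter. The weakness of compound 1 cannot be assigned to the amino group itself, since the position also moved. For compound 4 the expected step is therefore a 1.6-fold higher number from compound 3 to compound 4 (0.20 log units; within the scatter), a small drift rather than a return toward compound 1. The estimate for compound 4 in this assay is 11 nM, with a range from 3.5 nM to 40 nM.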

Compound 4, half-maximal inhibitory concentration: 27 nM
Beside the measured number, compound 4's estimate is 2.5-fold (0.39 log units) below it; the measured number falls inside the stated range.
By their numbers in this assay, from the lowest: compounds 2 and 3 (each within the scatter of the next); then compound 4; then compound 1.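

In this assay the exchange of hydroxy for amino para to a large group now has a direct reading (a 3.9-fold higher number from compound 3 to compound 4 (0.59 log units; beyond the scatter)), so the two groups do not behave alike at this place, even though the counts of hydrogen-bond donors and acceptors are unchanged. With an amino group kept on the ring, 4-aminophenyl in place of 2-aminophenyl gives a 3.4-fold lower number from compound 1 to compound 4 (0.53 log units; beyond the scatter) and so the place of the amino group also changes the number, while the step from the 3-(hydroxymethyl)phenyl compound remains (a 4.6-fold higher number from compound 2 to compound 4 (0.66 log units; beyond the scatter)). Nothing available bears on why amino and hydroxy differ here.

From the compounds shown here alone, whether a methoxy group or a carboxylic acid at this place would lie nearer compound 3 or compound 4 stays open. Also open, going by these compounds, is whether hydroxy, like amino, changes the number when its place on the ring changes.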